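The compounds below may be only part of what the source reports. "The series", "measured", "known", "first", "only" and "open" are said of these compounds alone.

Compound 1 `COc1ccc(-c2nnc(COc3ccc(C#N)c(F)c3)o2)cc1` and compound 2 `Cc1ccc(-c2nnc(COc3ccc(C#N)c(F)c3)o2)cc1` share one core and differ in a single spot: methyl in place of methoxy on an aromatic carbon. In a functional assay on MDA-MB-453 cells (Homo sapiens) for cytotoxicity, read by MTT assay, with a stated time of 48 h (on this read-out higher numbers stand for weaker inhibition and lower numbers for stronger inhibition), compound 1 gives 45500 nM. Compound 2 reaches only a limit of the assay, > 50000 nM, which is the limit of > 50000 nM in this assay, at which 1 of the 3 values shown sits. The measured step is therefore an at least 1.0-fold higher number from compound 1 to compound 2 (0.04 log units; that floor lies within the scatter). Compound 3 `COc1ccc(-c2nnc(COc3ccc(-c4nnco4)cc3)o2)cc1` is built on a different core; the difference between the two cores is not broken down here. In this assay compound 3 gives 36200 nM. Compound 4 `Cc1ccc(-c2nnc(COc3ccc(-c4nnco4)cc3)o2)cc1` has not yet been measured; it is related to compound 3 by the same change, (methyl in place of methoxy on an aromatic carbon), at the same place. Resting on an at least 1.0-fold higher number from compound 1 to compound 2 (0.04 log units; that floor lies within the scatter), the step from compound 3 to compound 4 is expected to be a 1.3-fold higher number from compound 3 to compound 4 (0.12 log units; within the scatter). Compound 4 is thus estimated at 48000 nM in this assay.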

Compound 4, half-maximal inhibitory concentration: > 50000 nM
Compound 4: only a limit was reported; the forecaster's own chance of this, stated with the estimate: 45%; at least 1.0-fold (0.01 log units) between middle value and limit.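

In this assay compound 4 gives > 50000 nM, which is a limit of the assay and not a number. As a step this reads an at least 1.3-fold higher number from compound 3 to compound 4 (0.14 log units; that floor lies within the scatter), so the change from 4-methoxyphenyl to 4-methylphenyl is not shown to move the result beyond the usual scatter on this core. The two cores therefore do not contradict each other, but this does not show that the change carries over with the same size: the same change on two cores in this assay, an at least 1.0-fold higher number (0.04 log units; that floor lies within the scatter) from compound 1 to compound 2 and an at least 1.3-fold higher number (0.14 log units; that floor lies within the scatter) from compound 3 to compound 4; the limit leaves it open whether they differ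

Going by these compounds, how far compound 2 and compound 4 lie past the limit stays open, and the limit constrains much of this small set: the limit of > 50000 nM in this assay, at which 2 of the 4 values shown sit. Also open is what an amine or a carboxylic acid in place of the methoxy would give on either core.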